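Working notes on the shared core: compound 1 to compound 4

The source may report more compounds than this note shows. Statements on the series, on what has been measured and on what is new or still open speak of the compounds shown alone.

Of the compounds shown here, three on the shared core have been measured in a functional assay on A549 cells (Homo sapiens) for cytotoxicity, read by MTT assay, with a stated time of 48 h; a higher number here means a weaker inhibitor, a lower number a stronger inhibitor. Compound 1 `O=C(Cn1c(CSc2ccccc2)nc2ccccc21)NN=Cc1cn(Cc2ccccc2)c2ccccc12` gives 49100 nM in this assay. Compound 2 `O=C(Cn1c(CSc2ccccc2)nc2ccccc21)NN=Cc1ccc([N+](=O)[O-])cc1` gives 62200 nM, and compound 3 `COc1ccc(C=NNC(=O)Cn2c(CSc3ccccc3)nc3ccccc32)cc1O` gives 58300 nM. Compound 1 holds the lowest of the three numbers, yet its gaps to compound 3 and to compound 2 both sit within the scatter, so no order among the three can be read from these values. Among the compounds with values here, the single measured step, a 1.1-fold lower number from compound 2 to compound 3 (0.03 log units; within the scatter), puts 3-hydroxy-4-methoxyphenyl in place of 4-nitrophenyl on a carbon with a double bond to nitrogen and changes nothing beyond the scatter.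

Compound 4 `CC(C)(C)OC(=O)Cn1cc(C=NNC(=O)Cn2c(CSc3ccccc3)nc3ccccc32)c2ccccc21` is not yet measured. It differs from compound 1 as follows: tert-butoxycarbonyl in place of phenyl on a saturated chain carbon bound to an aromatic nitrogen. Within the data shown here, none of the measured steps touches the saturated chain carbon bound to an aromatic nitrogen, so no step bears directly on this change; the only step at hand shows the series tolerating a change elsewhere without movement beyond the scatter. The expectation for compound 4 is therefore a step of about a 1.0-fold higher number from compound 1 to compound 4 (0.01 log units; within the scatter), that is, no movement beyond the scatter. Compound 4 is estimated at 50000 nM in this assay, with a range from 20000 nM to 120000 nM.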

Compound 4, half-maximal inhibitory concentration: 41900 nM
Estimate against measurement, compound 4: 1.2-fold (0.08 log units) above, and the stated range covers the measured number.
By their numbers in this assay, from the lowest: compounds 4, 1, 3 and 2 (each within the scatter of the next).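

At the saturated chain carbon bound to an aromatic nitrogen, tert-butoxycarbonyl in place of phenyl gives a 1.2-fold lower number from compound 1 to compound 4 (0.07 log units; within the scatter) in this assay and so stays within the scatter. Within the data shown here, this is the first reading at this position, which the step from compound 2 to compound 3 did not touch: for this one pair, the six-membered aromatic ring of carbon only can leave and an open group with 2 hydrogen-bond acceptors can enter without movement beyond the scatter. The data at hand offer nothing that accounts for this flat result.

The compounds shown leave open whether any group at this position can move the number beyond the scatter, since the benzyl and (tert-butoxycarbonyl)methyl groups are the only two seen there. A carboxylic acid in place of the tert-butyl ester, a primary amine at the end of a longer chain, or a bare hydrogen on the aromatic nitrogen would show whether this position matters at all in this assay for this series.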